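The source may hold more compounds than are shown below. What is called first, only, known or untested is meant among the compounds shown, and "the series" means these compounds.

The study concerns a set of fused polycyclic amines examined in an ADME assay on MDCK cells (Canis lupus familiaris) for cytotoxicity, with a stated time of 72 h; a higher number here means that more compound is tolerated, a lower number that less compound is tolerated. Compound 1, `C1=C[C@H]2[C@H]3[C@H]4[C@@H]1[C@@H]1[C@H]2[C@@H]2[C@H]3[C@@H]3CNC[C@@H]3[C@H]4[C@H]12`, gives 20000 nM in this assay. Compound 2, `C1C2[C@@H]3[C@H]2[C@@H]2C1[C@H]3[C@@H]1CNC[C@@H]12`, is the second member of the set. In this assay compound 2 reaches only the limit of > 100000 nM, so what is known of it is a bound rather than a number. Compound 2 therefore stands at the tolerant end of what this assay can report, as seen in the limit of > 100000 nM in this assay, at which 1 of the 2 values shown sits, while compound 1 alone yields a definite figure. Within the data shown here, no two measured compounds differ in only one place, so no measured step can be drawn between them.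

Compound 3, `N=C(N)N1C[C@@H]2[C@H](C1)[C@H]1C3CC4[C@H]([C@H]41)[C@@H]32`, has not yet been tested. It differs from compound 2 by a group of 3 heavy atoms (1 carbon, 2 nitrogen; no ring) in place of a hydrogen atom, on an amine nitrogen in a ring. Among the measured compounds shown here, with no measured step to lean on, the change in this assay on going from compound 2 to compound 3 is expected to be small, either none beyond the scatter or a modest move toward less tolerance. Compound 3 is accordingly expected to give about 80000 nM, within 25000 nM to 150000 nM. That expected change amounts to an at least 1.2-fold lower number from compound 2 to compound 3 (0.09 log units; that floor lies within the scatter).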

Compound 3, minimum cytotoxic concentration: > 100000 nM
Compound 3: only a limit was reported (the forecaster's own chance of this, stated with the estimate: 50%); middle value at least 1.2-fold (0.09 log units) from the limit.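

In this assay compound 3 gives > 100000 nM, which is a limit and not a number. Compound 2 also stands at a limit, and no step can be read between compound 2 and compound 3. The compounds shown leave open how much the group on the amine nitrogen in a ring changes tolerance, if at all.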